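Hydroxy in place of acetyl: expected microsomal clearance

The source may hold more compounds than are shown below. What is called first, only, known or untested is meant among the compounds shown, and "the series" means these compounds.

Two compounds of the series have numbers in an ADME assay on microsomes from liver (Homo sapiens) for metabolic stability, read by LC-MS, tested at 1 uM; on this read-out higher numbers stand for fast clearance and lower numbers for slow clearance. Compound 1 `CC[C@@H](C)n1ncn(-c2ccc(N3CCN(c4ccc(OC[C@@H]5CO[C@@](C)(c6ccc(F)cc6F)C5)cc4)CC3)cc2)c1=O` gives 37.4 mL.min-1.g-1 in this assay. Compound 2 `CC(=O)c1cccc(C(=O)Nc2ccc(N3CCN(c4ccc(OC[C@@H]5CO[C@@](C)(c6ccc(F)cc6F)C5)cc4)CC3)cc2)c1` gives 20 mL.min-1.g-1 in this assay. The only step between them, a 1.9-fold lower number from compound 1 to compound 2 (0.27 log units; within the scatter), places the two within the scatter of each other, so on the numbers shown compound 2 cannot be set apart from compound 1 in this read-out.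

Compound 3 `C[C@]1(c2ccc(F)cc2F)C[C@H](COc2ccc(N3CCN(c4ccc(NC(=O)c5cccc(O)c5)cc4)CC3)cc2)CO1` is not yet measured. It differs from compound 2 in one place: hydroxy in place of acetyl on an aromatic carbon, in words hydroxy in place of acetyl on an aromatic carbon. Among the measured compounds shown here, no measured step bears on this group. For the measured compounds named here, the single step from compound 1 to compound 2 exchanged a different part of the molecule and stayed within the scatter, so it offers no pull in either direction for the change at hand. With nothing to point up or down, the step expected here is no change at the digits printed from compound 2 to compound 3 (within the scatter), that is, nothing beyond the scatter. Compound 3 is therefore estimated at 20 mL.min-1.g-1 in this assay, with a range of 8 mL.min-1.g-1 to 50 mL.min-1.g-1.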

Compound 3, intrinsic clearance in microsomes in the Homo sapiens assay: 2.23 mL.min-1.g-1
Estimate against measurement, compound 3: 9.0-fold (0.95 log units) above; measured number outside the range, below it.
By their numbers in the Homo sapiens assay, from the lowest: compound 3; then compounds 2 and 1 (each within the scatter of the next).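

Among the compounds shown here, in the Homo sapiens assay compound 2 gives 20 mL.min-1.g-1 and compound 3 gives 2.23 mL.min-1.g-1 with hydroxy in place of acetyl on this aromatic carbon, meta to a large group, which is the first step that lies beyond the scatter (a 9.0-fold lower number from compound 2 to compound 3 (0.95 log units; beyond the scatter)), so the group held here matters to this read-out in a way the earlier pair could not show. The wider gap (a 17-fold lower number from compound 1 to compound 3 (1.22 log units; beyond the scatter)) sets compound 3 apart from both earlier compounds, which cannot be set apart from each other, and makes compound 3 the lowest of the three in clearance. In a physicochemical assay for solubility, read by LC-MS, in phosphate buffer, measured as kinetic solubility, at pH 7.4 (a lower number here means a less soluble compound, a higher number a more soluble compound), compound 2 gives 3130 nM and compound 3 gives 3130 nM across the same exchange (no change at the digits printed from compound 2 to compound 3 (within the scatter)), so the step in clearance stands with no step in solubility, and nothing measured on these compounds says why the clearance number falls.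

On these data alone, with only acetyl and hydroxy compared on this aromatic carbon, it remains open whether the lower clearance follows the arrival of hydroxy or the departure of acetyl, and a methoxy, an amine or a carboxylic acid in the same place would separate the two readings. Also open, as far as these compounds go, is whether hydroxy gives a step of this size on any other compound of the series.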